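A Carboxamide Exchanged for an Amino-Thiadiazole on One Core

This account rests on a few compounds, and the source may have more. Where it says the series, first, only, none or still open, it means among the compounds named here.

Compound 1 (`CNC(=O)c1ccc(-c2cnc3cnc(C(=O)N(C)c4ccc(C#N)cc4)cn23)cc1`) and compound 2 (`CN(C(=O)c1cn2c(-c3ccc(C(N)=O)cc3)cnc2cn1)c1ccc(F)cc1`) were both examined in an ADME assay on the whole organism for pharmacokinetics, with Mus musculus as the target, at a dose of 5 mg/kg by the intravenous route; a lower number here means that more of the compound stays in the plasma, a higher number that more of the compound sits outside the plasma. In this assay compound 1 gives 1.02 L/kg, and compound 2 gives 0.9 L/kg. Compound 1 stands at the head of these two numbers only nominally: its gap to compound 2 lies within the usual scatter of this kind of measurement, so the two values cannot be told apart. Compound 3 (`CN(C(=O)c1cn2c(-c3ccc(-c4nnc(N)s4)cc3)cnc2cn1)c1ccc(C#N)cc1`) has not yet been measured in this assay. It differs from compound 1 in one place: 5-amino-1,3,4-thiadiazol-2-yl in place of methylcarbamoyl on an aromatic carbon. For the measured compounds named here, no pair of measured compounds shows what such an exchange does in this assay; what is known is only that the two measured values sit close together. The step expected in this assay is a 1.0-fold lower number from compound 1 to compound 3 (0.01 log units; within the scatter), none beyond the scatter. Compound 3 is therefore expected to give about 1 L/kg in this assay, with a range from 0.5 L/kg to 2 L/kg.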

Compound 3, volume of distribution at steady state: 0.99 L/kg
Compound 3: the middle estimate sits 1.0-fold (0.00 log units) above what was measured; the measured number falls inside the stated range.
By their numbers in this assay, from the lowest: compounds 2, 3 and 1 (each within the scatter of the next).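

In this assay, for the compounds shown here, 5-amino-1,3,4-thiadiazol-2-yl in place of methylcarbamoyl on the aromatic carbon para to a large group gives a 1.0-fold lower number from compound 1 to compound 3 (0.01 log units; within the scatter), the first step that can be read at this position, and it shows that the two groups cannot be told apart there by this read-out. The exchange is not a small one by count: a group of 4 heavy atoms with no ring and 1 hydrogen-bond acceptor gives way to one of 6 heavy atoms, with a five-membered aromatic ring and 4 hydrogen-bond acceptors, and still the step lies within the scatter. Nothing at hand bears on why the two numbers coincide.

From the compounds shown here alone, this is a single pair on a single core, so it remains open whether the position would tolerate other groups in the same way, such as a carboxylic acid, a primary amine or a longer alkyl chain. Going by these compounds, it also remains open whether the same exchange would give so small a step with a different group in place of the nitrile on the other side of the shared core.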